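Swapping the sulfonyl aryl ring in a prostaglandin receptor antagonist

The source may report more compounds than this note shows. Statements on the series, on what has been measured and on what is new or still open speak of the compounds shown alone.

Of the compounds shown here, three with a shared core have been measured in a functional assay on CHO-K1 cells for antagonist activity at prostaglandin E2 receptor EP3 subtype (Homo sapiens), read by TR-FRET and cAMP accumulation, with a stated time of 30 min; a lower number here means a stronger inhibitor, a higher number a weaker inhibitor. Compound 1 `O=C(NS(=O)(=O)c1cc(Cl)c(Cl)s1)OC/C=C1\CCCc2cnn(Cc3ccc(Cl)cc3Cl)c21` gives 5 nM. Compound 2 `Cc1nc(C)c(S(=O)(=O)NC(=O)NC/C=C2\CCCc3cnn(Cc4ccc(Cl)cc4Cl)c32)s1` gives 4 nM, and compound 3 `O=C(NC/C=C1\CCCc2cnn(-c3ccc(C(F)(F)F)cc3)c21)NS(=O)(=O)c1cc(Cl)c(Cl)s1` gives 4 nM. Compound 1 carries the highest number of the three, but both compound 2 and compound 3 stand within the usual scatter of it, so no ranking among them can be drawn from these values. Compound 2 and compound 3 each differ from compound 1 in more than one place, so nothing about a single change can be read off from them.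

Compound 4 `O=C(NS(=O)(=O)c1ccc(Cl)cc1)OC/C=C1\CCCc2cnn(Cc3ccc(Cl)cc3Cl)c21` has not yet been measured. It differs from compound 1 in one place: 4-chlorophenyl in place of 4,5-dichlorothiophen-2-yl on a sulfonyl sulfur. For the measured compounds named here, no pair of measured compounds shows this change, so the direction and size of the step rest on expectation alone. It is estimated that compound 4 gives 10 nM in this assay , with a range of 3 nM to 35 nM. The step expected from compound 1 to compound 4 is a 2.0-fold higher number from compound 1 to compound 4 (0.30 log units; within the scatter), a modest loss that may not exceed the scatter.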

Compound 4, half-maximal inhibitory concentration: 92 nM
For compound 4 the middle estimate is 9.2-fold (0.96 log units) below the measured one, and the stated range ends below it.
By their numbers in this assay, from the lowest: compounds 2, 3 and 1 (each within the scatter of the next); then compound 4.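

In this assay, the sulfonyl aryl ring proves not to be freely interchangeable: replacing 4,5-dichlorothiophen-2-yl with 4-chlorophenyl on a sulfonyl sulfur gives an 18-fold higher number from compound 1 to compound 4 (1.26 log units; beyond the scatter), the only single-place step shown here. The two groups have the same count of heavy atoms, so that count alone does not track the step; they differ in ring type, in the ring sulfur and in the number of chlorines. Nothing measured here accounts for the size of this step.

The compounds shown leave open whether the ring sulfur or the second chlorine matters more, a question that 5-chlorothiophen-2-yl or 3,4-dichlorophenyl on the same sulfur could separate. On these data alone, it also remains open whether this swap would give a step of similar size on the other side chains and nitrogen substituents seen in compound 2 and compound 3.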